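Capping the phenol of compound 1 with 3-chlorobenzyl

The source may report more compounds than this note shows. Statements on the series, on what has been measured and on what is new or still open speak of the compounds shown alone.

Measured so far:
compound 1 `COc1cc(-c2nnc(SCc3cccc(Cl)c3)o2)ccc1O` gives 8290 nM in a functional assay on cells (T-cell, Mus musculus, strain BALB/c) for inhibition, read by MTT assay, with stated times of 24 h and 72 h; a higher number here means a weaker inhibitor, a lower number a stronger inhibitor
compound 2 `COc1cc(-c2nnc(SCc3ccccc3Cl)o2)ccc1O` gives 8430 nM in this assay
compound 3 `COc1cc(-c2nnc(SCc3ccc(Br)cc3)o2)ccc1O` gives 8830 nM in this assay

Compound 1 holds the lowest of the three numbers, but by slim margins: a 1.0-fold higher number from compound 1 to compound 2 (0.01 log units; within the scatter) and a 1.1-fold higher number from compound 1 to compound 3 (0.03 log units; within the scatter), as does a 1.0-fold higher number from compound 2 to compound 3 (0.02 log units; within the scatter). Each of these steps exchanges one halogenated benzyl for another on the saturated chain carbon bound to a sulfur, and none leaves the scatter. Compound 4 `COc1cc(-c2nnc(SCc3cccc(Cl)c3)o2)ccc1OCc1cccc(Cl)c1` differs from compound 1 elsewhere: 3-chlorobenzyl in place of hydrogen on an oxygen on an aromatic ring. For the measured compounds named here, no measured step touches this oxygen, so the three steps bear on it only indirectly, showing that small changes at the sulfur-bound carbon move nothing in this assay. The expectation for compound 4 therefore rests on compound 1 at 8290 nM with a wide range. Compound 4 is estimated at 9000 nM, between 3000 nM and 27000 nM. The expected step of a 1.1-fold higher number from compound 1 to compound 4 (0.04 log units; within the scatter) stays within the scatter.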

Compound 4, half-maximal inhibitory concentration: 15800 nM
Compound 4: middle estimate off by 1.8-fold (0.24 log units), on the low side; low and high end bracket the measured number.
By their numbers in this assay, from the lowest: compounds 1, 2, 3 and 4 (each within the scatter of the next).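

For the compounds shown here, this is the first change at the oxygen on an aromatic ring, and the swap of hydroxy to (3-chlorobenzyl)oxy gives a 1.9-fold higher number from compound 1 to compound 4 (0.28 log units; within the scatter) in this assay. The free hydroxy is therefore not needed to keep the number within the scatter of compound 1, even with a 3-chlorobenzyl of 8 heavy atoms on that oxygen. No evidence given here bears on this result.

As far as these compounds go, whether a methyl group or a chain ending in a carboxylic acid on this oxygen would also stay within the scatter remains open. Also open, from the compounds shown here alone, is how 3-chlorobenzyl there behaves alongside the 2-chlorophenyl of compound 2 or the 4-bromophenyl of compound 3.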